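Removal of the aromatic methyl from compound 1

The source may hold more compounds than are shown below. What is called first, only, known or untested is meant among the compounds shown, and "the series" means these compounds.

Measured compounds:
compound 1 `COc1cc(C(=O)/C=C\Nc2ccc(-c3nc4cc(OC)c(OC)c(OC)c4s3)cc2C)cc(OC)c1OC` gives 23300 nM
compound 2 `COc1ccc(C(=O)/C=C\Nc2ccc(-c3nc4cc(OC)c(OC)c(OC)c4s3)cc2C)cc1F` gives 1690 nM
compound 3 `COc1cc(OC)c2sc(-c3ccc(N/C=C\C(=O)c4cc(OC)c(OC)c(OC)c4)c(C)c3)nc2c1` gives 14400 nM

In a functional assay on A549 cells (Homo sapiens) for antiproliferative activity, read by sulforhodamine B assay, with a stated time of 48 h (on this read-out higher numbers stand for weaker inhibition and lower numbers for stronger inhibition), compound 1 stands highest of the three numbers. The step of a 1.6-fold lower number from compound 1 to compound 3 (0.21 log units; within the scatter) stays within the scatter, whereas a 14-fold lower number from compound 1 to compound 2 (1.14 log units; beyond the scatter) lies beyond it.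

Compound 4 `COc1cc(C(=O)/C=C\Nc2ccc(-c3nc4cc(OC)c(OC)c(OC)c4s3)cc2)cc(OC)c1OC` differs from compound 1 by hydrogen in place of methyl on an aromatic carbon. Going by the values given here, no measured step removes a methyl; the only change at an aromatic carbon of the shared core, a 1.6-fold lower number from compound 1 to compound 3 (0.21 log units; within the scatter), removed a methoxy and stayed within the scatter, and the large step concerned the group on the carbonyl carbon. Nothing measured therefore points to a step beyond the scatter. Compound 4 is expected to give about 23000 nM, within 8000 nM to 70000 nM, meaning a 1.0-fold lower number from compound 1 to compound 4 (0.01 log units; within the scatter).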

Compound 4, half-maximal inhibitory concentration: 15500 nM
Compound 4: middle estimate off by 1.5-fold (0.17 log units), on the high side; low and high end bracket the measured number.
By their numbers in this assay, from the lowest: compound 2; then compounds 3, 4 and 1 (each within the scatter of the next).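

In this assay, hydrogen in place of methyl on this aromatic carbon gives a 1.5-fold lower number from compound 1 to compound 4 (0.18 log units; within the scatter) and so does not separate the two compounds. Going by these compounds alone, compounds 1, 2 and 3 all carry this methyl, so this is the first reading at this position, and with the group on the carbonyl carbon of compound 1 the methyl is not required for the activity seen. Nothing available explains this outcome.

On these data alone, whether the same swap stays within the scatter with the 3-fluoro-4-methoxyphenyl group of compound 2 remains open. So does the effect of an amine, a hydroxyl or a longer alkyl chain on this carbon.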